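Chromene chalcones: a chlorohydroxyphenyl analogue follows a pyridyl limit

The source may hold more compounds than are shown below. What is called first, only, known or untested is meant among the compounds shown, and "the series" means these compounds.

Measured compounds:
compound 1 `COc1ccc(C(=O)/C=C/c2ccc(N3CCCC3)cc2)c2c1C=CC(C)(C)O2` — 7150 nM
compound 2 `COc1ccc(C(=O)/C=C/c2ccc3ccccc3n2)c2c1C=CC(C)(C)O2` — 2250 nM
compound 3 `COc1ccc(/C=C/C(=O)c2ccc(OC)c3c2OC(C)(C)C=C3)cn1` — > 10000 nM

The three measured compounds share one core and differ only in the ring attached to the double-bonded chain. In a functional assay on SW-620 cells (Homo sapiens) for antiproliferative activity, read by MTT assay, with a stated time of 24 h (on this read-out higher numbers stand for weaker inhibition and lower numbers for stronger inhibition), compound 1 gives 7150 nM and compound 2 gives 2250 nM. Compound 3, which carries the 6-methoxypyridin-3-yl ring, reaches only a limit of the assay, > 10000 nM, so its true value is not known; it sits at the top of the numbers shown, as the limit of > 10000 nM in this assay, at which 1 of the 3 values shown sits, records.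

Compound 4 `COc1ccc(C(=O)/C=C/c2cc(Cl)ccc2O)c2c1C=CC(C)(C)O2` has not been measured. It differs from compound 3 by 5-chloro-2-hydroxyphenyl in place of 6-methoxypyridin-3-yl on a double-bonded chain carbon bound to a double-bonded chain carbon. Within the data shown here, no measured pair in this set separates a change of this kind, so the size of the step can only be guessed from the spread of compound 1 and compound 2, both of which carry carbon-only or bicyclic rings at the same place and return numbers rather than limits. Compound 4 is therefore expected to return a number, with a step of an at least 1.6-fold lower number from compound 3 to compound 4 (0.22 log units; that floor lies within the scatter) toward stronger inhibition. Compound 4 is estimated at 6000 nM, within 2500 nM to 15000 nM, though a limit remains possible.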

Compound 4, half-maximal inhibitory concentration: 4230 nM
Compound 4: middle estimate off by 1.4-fold (0.15 log units), on the high side, and the stated range covers the measured number.
By their numbers in this assay, from the lowest: compounds 2, 4 and 1 (each within the scatter of the next, the first and the last beyond it). At a limit, above all of these: compound 3.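

In this assay the exchange of 6-methoxypyridin-3-yl for 5-chloro-2-hydroxyphenyl on a double-bonded chain carbon bound to a double-bonded chain carbon gives an at least 2.3-fold lower number from compound 3 to compound 4 (0.37 log units; beyond the scatter) and so turns a limit into a number. Among these compounds, this is the first step in the set that can be read between two compounds differing in one place, and it shows that the ring at this place alone can shift the read-out beyond the scatter. Compound 3 stands at a limit of the assay, so the step gives only a floor and not a full size: the limit of > 10000 nM in this assay, at which 1 of the 4 values shown sits.

The compounds shown leave open whether the chlorine, the hydroxyl or the loss of the pyridine nitrogen carries the step. As far as these compounds go, how a carboxylic acid or an amine on this ring would read also remains open.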